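Three Aziridinyl Quinones and a Carbamate-Bearing Fourth

The compounds below may be only part of what the source reports. "The series", "measured", "known", "first", "only" and "open" are said of these compounds alone.

Measured so far:
- compound 1, `CCC(OC)C1=C(N2CC2)C(=O)C(C)=C(N2CC2)C1=O`: 5.33
- compound 2, `CC(C)C1=C(N2CC2)C(=O)C=C(N2CC2)C1=O`: 5.37
- compound 3, `CCC1=C(N2CC2)C(=O)C(C(COC(N)=O)OC)=C(N2CC2)C1=O`: 5.22

All three were tested in a functional assay on L1210 cells (Mus musculus), with a stated time of 12 days; a lower number here means a less potent compound, a higher number a more potent compound, by a factor of ten per unit of this negative logarithm. Compound 1 stands second highest of the three numbers, yet its distances to compound 2 and to compound 3 both lie within the usual scatter, so the three values cannot be told apart.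

Compound 4, `CC1=C(N2CC2)C(=O)C(CCCOC(N)=O)=C(N2CC2)C1=O`, has not been measured. It differs from compound 1 as follows: a group of 7 heavy atoms (4 carbon, 1 nitrogen, 2 oxygen; no ring) in place of a group of 5 heavy atoms (4 carbon, 1 oxygen; no ring), on a double-bonded ring carbon. Among the measured compounds shown here, no step between two measured compounds isolates such a change. Given how closely the three known values sit, the step of a number 0.03 log units lower from compound 1 to compound 4 (within the scatter) is expected to be small, with no clear direction beyond the scatter. For compound 4 the estimate in this assay is 5.3, between 4.85 and 5.75.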

Compound 4, logarithm of the reciprocal of the active concentration, log(1/C): 5.93
Estimate against measurement, compound 4: 0.63 log units below, and the stated range ends below it.
By their numbers in this assay, from the lowest: compounds 3, 1 and 2 (each within the scatter of the next); then compound 4.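

In this assay the three earlier compounds lay within the scatter of one another, so they gave no sign that this double-bonded ring carbon could move the read-out. Replacing 1-methoxypropyl with the carbamate-bearing chain gives a number 0.60 log units higher from compound 1 to compound 4 (beyond the scatter) and shows that the group on this carbon can matter. Nothing shown here gives a reason for this rise. Going by these compounds, it remains open whether the step belongs to the carbamate end or to the chain as a whole. A plain propyl chain, or a chain ending in a hydroxyl or an amine, would help separate the two.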